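From pyrrolidin-1-yl to propylamino on a shared core

This account rests on a few compounds, and the source may have more. Where it says the series, first, only, none or still open, it means among the compounds named here.

In an ADME assay on BCBL1 cells (Homo sapiens) for cytotoxicity, with a stated time of 7 days (on this read-out lower numbers stand for higher toxicity in this test and higher numbers for lower toxicity in this test), compound 3 `Nc1nc(N2CCCC2)c2ncn(/C=C3/CC3(CO)CO)c2n1` gives > 20000 nM, which is a limit and not a number. Compound 1 `CC(C)Nc1nc(N)nc2c1ncn2/C=C1/CC1(CO)CO` gives > 20000 nM, and this too is a limit. Compound 2 `Nc1nc(NC2CC2)c2ncn(/C=C3/CC3(CO)CO)c2n1` gives a true number, 71500 nM. Compound 3 therefore stands with compound 1 at the limit of > 20000 nM in this assay, at which 2 of the 3 values shown sit, and it has no exact place on the scale of this assay.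

Compound 4 `CCCNc1nc(N)nc2c1ncn2/C=C1/CC1(CO)CO` carries propylamino in place of pyrrolidin-1-yl on an aromatic carbon, next to the ring nitrogen: propylamino in place of pyrrolidin-1-yl on an aromatic carbon. Within the data shown here, three measured steps bear on this change: a step that the two limits leave unreadable from compound 1 to compound 3, a step that the limit leaves unreadable from compound 2 to compound 3 and a step that the limit leaves unreadable from compound 1 to compound 2. None of them has a readable size, so they offer no firm guide to the size of the new step. All three measured compounds do sit on the low-toxicity side of the read-out, and the same is expected of compound 4, which may also return only a limit. The estimated step is a step that the limit leaves unreadable from compound 3 to compound 4, and no firm direction is expected. For compound 4 the estimated value is 45000 nM, with an expected range from 20000 nM to 100000 nM.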

Compound 4, half-maximal cytotoxic concentration: > 20000 nM
Compound 4 ended at the assay's limit; the forecaster's own chance of this, stated with the estimate: 55%; the middle value is on the limit's open side.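

In this assay compound 4 gives > 20000 nM, which is a limit and not a number. Its steps from compound 1, compound 2 and compound 3 cannot be read, because the result joins the others at the same limit: the limit of > 20000 nM in this assay, at which 3 of the 4 values shown sit.

As far as these compounds go, whether propylamino, isopropylamino and pyrrolidin-1-yl differ at all on the shared core stays open.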